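The compounds below may be only part of what the source reports. "The series", "measured", "known", "first", "only" and "open" are said of these compounds alone.

Measured compounds:
compound 1 `CCCCOC1=C(C(=O)c2ccccc2)C(c2ccc(Br)cc2)N(CCCn2ccnc2)C1=O` with 32400 nM in a functional assay on U2OS cells (Homo sapiens) for antiproliferative activity, read by MTT assay, with a stated time of 72 h; on this read-out lower numbers stand for stronger inhibition and higher numbers for weaker inhibition
compound 2 `O=C(C1=C(Nc2ccc(F)cc2)C(=O)N(CCCn2ccnc2)C1c1ccc(Br)cc1)c1ccccc1` with 30000 nM in this assay

In this assay compound 2 and compound 1 lie within the scatter of each other, as a 1.1-fold lower number from compound 1 to compound 2 (0.03 log units; within the scatter) shows. Compound 3 `O=C(C1=C(Nc2cccc(Br)c2)C(=O)N(CCCn2ccnc2)C1c1ccc(Br)cc1)c1ccccc1` differs from compound 2 by 3-bromophenyl in place of 4-fluorophenyl on an amine nitrogen. For the measured compounds named here, no measured step changes the group on this amine nitrogen; the one step known, a 1.1-fold lower number from compound 1 to compound 2 (0.03 log units; within the scatter), replaced the whole butoxy group and stayed within the scatter. With nothing pointing either way, compound 3 is expected to stay close to compound 2, giving no change at the digits printed from compound 2 to compound 3 (within the scatter). The estimate for compound 3 in this assay is 30000 nM, with a range from 10000 nM to 90000 nM.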

Compound 3, half-maximal inhibitory concentration: 11900 nM
For compound 3 the middle estimate is 2.5-fold (0.40 log units) above the measured one; the measured number falls inside the stated range.
By their numbers in this assay, from the lowest: compound 3; then compounds 2 and 1 (each within the scatter of the next).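

In this assay the group on this amine nitrogen does change the number: a 2.5-fold lower number from compound 2 to compound 3 (0.40 log units; beyond the scatter). The earlier swap at the double-bonded ring carbon stayed within the scatter, while (3-bromophenyl)amino is set apart from butoxy, with a 2.7-fold lower number from compound 1 to compound 3 (0.43 log units; beyond the scatter). No measurement at hand explains either step.

3-bromophenyl differs from 4-fluorophenyl in both the halogen and where it sits, and the compounds shown cannot separate these two changes. On these data alone, how a plain phenyl or a pyridyl group on this nitrogen would read also stays open.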